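Acid and ester analogues measured for cytotoxicity in Raji cells

This account rests on a few compounds, and the source may have more. Where it says the series, first, only, none or still open, it means among the compounds named here.

Compound 1 `CC(C)N(Cc1cccc(OCCCCCC(=O)O)c1)C(=O)c1ccc(-c2cccc3ccccc23)cc1`: in an ADME assay on Raji cells (Homo sapiens) for cytotoxicity, read by CellTiter-Glo and resazurin assay, with a stated time of 72 h (a lower number here means that less compound is needed, a higher number that more compound is needed for the effect), compound 1 gives > 26000 nM, which is a limit of the assay rather than a number.
Compound 2 `CC(=O)Nc1cccc(-c2ccc(C(=O)N(Cc3cccc(OCCCCCC(=O)O)c3)C(C)C)cc2)c1`: in this assay compound 2 gives > 26000 nM, again only a limit.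
Compound 3 `CCOC(=O)CCCCCOc1cccc(CN(C(=O)c2ccc(-c3cccc4ccccc34)cc2)C(C)C)c1`: in this assay compound 3 gives > 26000 nM, also a limit.

Compound 2 differs from compound 1 by 3-acetamidophenyl in place of naphthalen-1-yl on an aromatic carbon, and the step that the two limits leave unreadable from compound 1 to compound 2 cannot be sized, since both values sit at the limit of > 26000 nM in this assay, at which 3 of the 3 values shown sit. Compound 3 differs from compound 1 by ethyl in place of hydrogen on an oxygen next to a carbonyl group, so the core of compound 3 carries an ester where compound 1 carries an acid. Compound 4 `CCOC(=O)CCCCCOc1cccc(CN(C(=O)c2ccc(-c3cccc(NC(C)=O)c3)cc2)C(C)C)c1` is not yet measured; it differs from compound 3 by 3-acetamidophenyl in place of naphthalen-1-yl on an aromatic carbon, the same change that leads from compound 1 to compound 2, at the same place.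

Because all three measured values sit at the limit of > 26000 nM in this assay, at which 3 of the 3 values shown sit, compound 4 is expected to stay at that limit too, with an estimated step that the limit leaves unreadable from compound 3 to compound 4. The estimate for compound 4 in this assay is 30000 nM, with a range from 13000 nM to 100000 nM.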

Compound 4, half-maximal effective concentration: > 26000 nM
Compound 4: only a limit was reported; the forecaster's own chance of this, stated with the estimate: 85%; the middle value lies beyond the limit too.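

Neither the change from compound 3 to compound 4 nor the change from compound 2 to compound 4 can be sized, because these results are limits and not numbers: the limit of > 26000 nM in this assay, at which 4 of the 4 values shown sit.
The compounds shown leave open how much of compounds 1 to 4 would be needed for an effect in this assay, and whether either change alters that amount at all.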